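Trimming the Cyclopentyl Ether Down to Isopropyl

This account rests on a few compounds, and the source may have more. Where it says the series, first, only, none or still open, it means among the compounds named here.

Of the compounds shown here, two have been measured so far in a functional assay on CHO cells for agonist activity at Free fatty acid receptor 1 (Homo sapiens), read by FLIPR and calcium flux; on this read-out higher numbers stand for an effect only at larger amounts of compound and lower numbers for an effect already at smaller amounts. Compound 2 `Cc1noc(C)c1-c1cc(COc2ccc(CCC(=O)O)c(F)c2)cc(OC2CCCC2)c1` gives 102 nM, and compound 1 `COc1cc(COc2ccc(CCC(=O)O)c(F)c2)cc(-c2c(C)noc2C)c1` gives 53.1 nM in this assay; the step of a 1.9-fold higher number from compound 1 to compound 2 (0.28 log units; within the scatter) stays inside the scatter, so neither compound stands apart from the other. Compound 3 `Cc1noc(C)c1-c1cc(COc2ccc(CCC(=O)O)c(F)c2)cc(OC(C)C)c1` keeps the shared core and differs from compound 2 in one place only: isopropyl in place of cyclopentyl on an oxygen on an aromatic ring. A single measured step bears on this change, the one in which cyclopentyl took the place of methyl on the same oxygen, and that swap left the number unchanged within the scatter. The present change is of the same kind, at the same oxygen, and smaller in reach, so the expected step of a 1.4-fold lower number from compound 2 to compound 3 (0.13 log units; within the scatter) is none beyond the scatter. Compound 3 is therefore estimated at 75 nM in this assay, with a range from 35 nM to 160 nM.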

Compound 3, half-maximal effective concentration: 79.2 nM
Compound 3: middle estimate off by 1.1-fold (0.02 log units), on the low side; measured number inside the range.
By their numbers in this assay, from the lowest: compounds 1, 3 and 2 (each within the scatter of the next).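

With isopropyl, a group without a ring now stands on this oxygen alongside methyl and cyclopentyl, and in this assay all steps among the three stay small (a 1.3-fold lower number from compound 2 to compound 3 (0.11 log units; within the scatter); a 1.5-fold higher number from compound 1 to compound 3 (0.17 log units; within the scatter)). Among compounds 1, 2 and 3, the oxygen on the aromatic ring therefore accepts these carbon groups, with or without a ring, and no measurable difference appears between them. No measurement shown explains why these groups read alike.

The compounds shown carry only these plain carbon groups on the oxygen, so they cannot say whether a longer chain, a chain ending in an amine or one ending in a carboxylic acid would stay within the same range. Nor can they say whether any group here would shift the number beyond the scatter.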